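The source may report more compounds than this note shows. Statements on the series, on what has been measured and on what is new or still open speak of the compounds shown alone.

Measured in an assay on CHO cells for displacement of a labelled ligand from adenosine receptor A2b (Homo sapiens), read by scintillation counting, with a stated time of 75 min; a lower number here means a stronger inhibitor, a higher number a weaker inhibitor:
compound 1, `O=C(CCCc1ccccc1)Nc1nc2ccccc2c(=O)s1`: > 1000 nM
compound 2, `O=C(CCc1ccccc1Br)Nc1nc2ccccc2c(=O)s1`: > 1000 nM

Both values are limits of this assay, not numbers; (the limit of > 1000 nM in this assay, at which 2 of the 2 values shown sit). Compound 2 therefore stands only at a limit, with > 1000 nM in this assay. Going by the values given here, the single measured step, a step that the two limits leave unreadable from compound 1 to compound 2, is unreadable between the two limits.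

Compound 3, `O=C(CCc1ccccc1F)Nc1nc2ccccc2c(=O)s1`, differs from compound 2 by fluoro in place of bromo on an aromatic carbon. Among the compounds with values here, no measured step gives a readable size that bears on this change, so no direction beyond the scatter can be read for it. Compound 3 is expected to remain at the limit, an estimated 2500 nM with range 800 nM to 10000 nM, the expected step being a step that the limit leaves unreadable from compound 2 to compound 3.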

Compound 3, inhibition constant: 801 nM
For compound 3 the middle estimate is 3.1-fold (0.49 log units) above the measured one; the range from low to high includes it.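

Fluoro in place of bromo on this aromatic carbon, ortho to a large group, gives the first value in the series that is a number and not a limit: compound 3 reads 801 nM. The change shows an at least 1.2-fold lower number from compound 2 to compound 3 (0.09 log units; that floor lies within the scatter), and 2-fluorophenyl in place of benzyl shows an at least 1.2-fold lower number from compound 1 to compound 3 (0.09 log units; that floor lies within the scatter). Both sizes are floors only, so the true gaps cannot be read.

Open, from the compounds shown here alone, is whether chloro or methoxy on this carbon also gives a number, and how an unsubstituted phenyl on the same chain reads.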